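Trading Chloro for Hydrogen on a Shared Core

The source may report more compounds than this note shows. Statements on the series, on what has been measured and on what is new or still open speak of the compounds shown alone.

Of the compounds shown here, three have so far been tested in a functional assay on SNB-19 cells (Homo sapiens) for cytotoxicity, read by sulforhodamine B assay, with a stated time of 48 h; on this read-out lower numbers stand for higher toxicity in this test and higher numbers for lower toxicity in this test. Compound 3 `ClCc1cccc(Cn2cnc3nc(Cl)nc(Cl)c32)c1` gives 5120 nM. Compound 1 `ClCc1cccc(Cn2cnc3ncnc(Cl)c32)c1` gives 6760 nM in this assay. The change between them is hydrogen in place of chloro on an aromatic carbon, and it produced a 1.3-fold higher number from compound 3 to compound 1 (0.12 log units; within the scatter). Compound 2 `ClCc1ccc(Cn2cnc3nc(Cl)nc(Cl)c32)cc1` reaches only > 100000 nM in this assay, which is a limit of the assay and not a number. The difference between the cores of compound 2 and compound 3 is not broken down here. Compound 4 `ClCc1ccc(Cn2cnc3ncnc(Cl)c32)cc1` has not yet been measured in this assay, and it stands to compound 2 as compound 1 stands to compound 3, through the same change, (hydrogen in place of chloro on an aromatic carbon). The earlier step between compound 3 and compound 1 stayed within the scatter, and compound 2 sits at the limit of > 100000 nM in this assay, at which 1 of the 3 values shown sits. Compound 4 is therefore expected to show roughly a step that the limit leaves unreadable from compound 2 to compound 4 and to land near 150000 nM in this assay, most probably again only as a limit.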

Compound 4, concentration lethal to 50% of the cells: 5750 nM
Beside the measured number, compound 4's estimate is 26-fold (1.42 log units) above it, and the stated range ends above it.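

In this assay, hydrogen in place of chloro on an aromatic carbon gives an at least 17-fold lower number from compound 2 to compound 4 (1.24 log units; beyond the scatter), so the change does not carry from one core to the other with the same size: the same change on two cores in this assay, a 1.3-fold higher number (0.12 log units; within the scatter) from compound 3 to compound 1 and an at least 17-fold lower number (1.24 log units; beyond the scatter) from compound 2 to compound 4, at least 22-fold (1.36 log units) apart, beyond the scatter of two such steps

The value of compound 2, > 100000 nM, is a limit of the assay and not a number. These two pairs give no rule for other cores, and they do not tell why the two steps differ.

The compounds shown leave open what an amine or a methoxy group would do in place of the chloro between two ring nitrogen atoms, on either core. They also leave open whether the same change on a further core would follow the small step or the large one.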